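Amide nitrogen substituents in a modulator series

A few compounds are considered here, and "the series" means these few. Any claim that something is new, unique, unknown or untested is made for them only; others in the source may bear on it.

Measured compounds:
- compound 1 `NC(=O)c1ccc(C#Cc2ccccc2)nc1`: 6600 nM
- compound 2 `CC(C)CCNC(=O)c1ccc(C#Cc2ccccc2)nc1`: 510 nM
- compound 3 `O=C(NCc1ccco1)c1ccc(C#Cc2ccccc2)nc1`: 180 nM

All three values come from a functional assay on BHK cells for positive allosteric modulation of metabotropic glutamate receptor 5 (Homo sapiens), read by FLIPR and calcium flux; a lower number here means that less compound is needed, a higher number that more compound is needed for the effect. Compound 3 stands lowest of the three, with a 37-fold lower number from compound 1 to compound 3 (1.56 log units; beyond the scatter) and a 2.8-fold lower number from compound 2 to compound 3 (0.45 log units; beyond the scatter), both beyond the scatter; the remaining measured step is a 13-fold lower number from compound 1 to compound 2 (1.11 log units; beyond the scatter).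

Compound 4 `O=C(NCc1ccsc1)c1ccc(C#Cc2ccccc2)nc1` differs from compound 3 by thiophen-3-yl in place of furan-2-yl on a saturated chain carbon bound to an amide-type nitrogen. Among the measured compounds shown here, no measured step swaps one five-membered aromatic ring for another; the steps that bear on it, from compound 1 to compound 2 and from compound 2 to compound 3, concern adding or reshaping the whole substituent rather than its ring heteroatom. A change within the scatter is therefore expected in this assay, a 1.1-fold higher number from compound 3 to compound 4 (0.05 log units; within the scatter). Compound 4 is estimated at 200 nM, with a range of 80 nM to 500 nM.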

Compound 4, half-maximal effective concentration: 140 nM
For compound 4 the middle estimate is 1.4-fold (0.15 log units) above the measured one, and the stated range covers the measured number.
By their numbers in this assay, from the lowest: compounds 4 and 3 (each within the scatter of the next); then compound 2; then compound 1.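

In this assay, thiophen-3-yl in place of furan-2-yl on a saturated chain carbon bound to an amide-type nitrogen gives a 1.3-fold lower number from compound 3 to compound 4 (0.11 log units; within the scatter), so this position accepts one five-membered aromatic ring for another with no change beyond the scatter. The second ring keeps the gain over the isobutyl end of compound 2, with a 3.6-fold lower number from compound 2 to compound 4 (0.56 log units; beyond the scatter), and over the unsubstituted amide, with a 47-fold lower number from compound 1 to compound 4 (1.67 log units; beyond the scatter). Nothing measured accounts for these steps.

Oxygen versus sulfur and the ring's attachment point change together here, so furan-3-yl or thiophen-2-yl would be needed to separate them. Also open, from the compounds shown here alone, is how a phenyl ring, a pyridine ring or a longer chain between ring and amide nitrogen would read.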